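The source may hold more compounds than are shown below. What is called first, only, known or untested is meant among the compounds shown, and "the series" means these compounds.

Measured compounds, each tested in an ADME assay on PC-3 cells (Homo sapiens) for cytotoxicity, read by sulforhodamine B assay, with a stated time of 48 h, tested at 10 uM; a lower number here means less inhibition, a higher number more inhibition at the concentration tested (going by the name of the read-out):

Compound 1, `COc1nc2ccc(Br)cc2cc1C(c1ccccc1)n1cc(C2CC2)nn1`, gives 22.6%.
Compound 2, `COc1nc2ccc(Br)cc2cc1C(c1ccccc1)n1cc(-c2cccc(F)c2)nn1`, gives 14.6%.
Compound 3, `COc1nc2ccc(Br)cc2cc1C(c1ccccc1)n1cc(-c2ccc(OC(F)(F)F)cc2)nn1`, gives 21.6%.

All three share one core and differ only in the group attached to one aromatic carbon of the five-membered ring. On the numbers, compound 3 sits close to both partners: the step of a number 1 percentage points lower from compound 1 to compound 3 (within the scatter) and the step of a number 7 percentage points higher from compound 2 to compound 3 (within the scatter) are each within the scatter, so none of these three can be told apart with confidence.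

Compound 4, `COc1nc2ccc(Br)cc2cc1C(c1ccccc1)n1cc(CCCCCO)nn1`, has not yet been measured. It differs from compound 3 in one place: 5-hydroxypentyl in place of 4-(trifluoromethoxy)phenyl on an aromatic carbon. The three measured steps all swap the group at that same carbon, and all three, a number 8 percentage points lower from compound 1 to compound 2 (within the scatter), a number 1 percentage points lower from compound 1 to compound 3 (within the scatter) and a number 7 percentage points higher from compound 2 to compound 3 (within the scatter), stay within the scatter. Among the measured compounds shown here, none of them, however, brings in a chain carrying a hydroxyl; no measured pair speaks directly to such a change. With only those steps as a guide, the swap in this assay is expected to produce no step beyond the scatter. Compound 4 is therefore estimated to give 20%, with a range from 8% to 32%. The expected step is a number 1.6 percentage points lower from compound 3 to compound 4 (within the scatter).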

Compound 4, a percentage reported as inhibition, at one concentration (the size of the read-out at that concentration, not a potency): 12.9%
Beside the measured number, compound 4's estimate is 7.1 percentage points above it; the range from low to high includes it.
By their numbers in this assay, from the lowest: compounds 4, 2, 3 and 1 (each within the scatter of the next).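

Among the compounds shown here, compound 4 brings the first open chain to this aromatic carbon, and the first group with a hydroxyl, yet in this assay every new step stays within the usual scatter of the measurement: there is (a number 8.7 percentage points lower from compound 3 to compound 4 (within the scatter)), (a number 1.7 percentage points lower from compound 2 to compound 4 (within the scatter)) and (a number 9.7 percentage points lower from compound 1 to compound 4 (within the scatter)). The position has now carried a cyclopropyl, two substituted phenyl rings and a ring-free 5-hydroxypentyl chain, and none of these swaps gives a step that can be told apart from repeat-to-repeat variation, so the four compounds cannot be ranked with confidence. Nothing else available here bears on why these numbers fall where they do.

As far as these compounds go, whether the hydroxyl or the chain itself matters stays open, as does what a plain pentyl chain, a longer chain, or an amine or carboxylic acid at the chain end would give. From the compounds shown here alone, all of these numbers also come from a single concentration in a single cell type, so how the compounds compare at other concentrations, or in other cells, remains unknown.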